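From 3-chlorophenyl to 3-iodophenyl

This account rests on a few compounds, and the source may have more. Where it says the series, first, only, none or still open, it means among the compounds named here.

In a functional assay on MDA-MB-231 cells (Homo sapiens) for antiproliferative activity, read by sulforhodamine B assay, with a stated time of 48 h (a higher number here means a weaker inhibitor of growth, a lower number a stronger inhibitor of growth), compound 1 (`Cc1cc2c(cc1C)C(Cl)=C(c1nnc(-c3ccccc3)o1)CCC2`) gives 2760 nM, compound 2 (`Cc1cc2c(cc1C)C(Cl)=C(c1nnc(-c3ccc(F)cc3)o1)CCC2`) gives 1400 nM and compound 3 (`Cc1cc2c(cc1C)C(Cl)=C(c1nnc(-c3cccc(Cl)c3)o1)CCC2`) gives 3310 nM. Two gaps place that last value: a 1.2-fold higher number from compound 1 to compound 3 (0.08 log units; within the scatter), and a 2.4-fold higher number from compound 2 to compound 3 (0.37 log units; beyond the scatter). The change to compound 4 (`Cc1cc2c(cc1C)C(Cl)=C(c1nnc(-c3cccc(I)c3)o1)CCC2`) is iodo in place of chloro on an aromatic carbon, meta to a large group (iodo in place of chloro on an aromatic carbon). For the measured compounds named here, no iodo compound has been measured yet. The closest evidence is halogen in place of hydrogen, and both such steps stay within the scatter: a 2.0-fold lower number from compound 1 to compound 2 (0.29 log units; within the scatter), and a 1.2-fold higher number from compound 1 to compound 3 (0.08 log units; within the scatter). No step beyond the scatter is therefore expected in this assay. The expected step is a 1.1-fold lower number from compound 3 to compound 4 (0.04 log units; within the scatter). Compound 4 is estimated at 3000 nM, with an expected range of 1300 nM to 7000 nM.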

Compound 4, concentration for 50% growth inhibition: 2670 nM
Compound 4: the middle estimate sits 1.1-fold (0.05 log units) above what was measured; the range from low to high includes it.
By their numbers in this assay, from the lowest: compounds 2, 4, 1 and 3 (each within the scatter of the next, the first and the last beyond it).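

In this assay, iodo and chloro at this place read alike, with a 1.2-fold lower number from compound 3 to compound 4 (0.09 log units; within the scatter), and iodo in place of hydrogen gives a 1.0-fold lower number from compound 1 to compound 4 (0.01 log units; within the scatter). For the compounds shown here, compound 4 also stays within the scatter of the 4-fluorophenyl compound, with a 1.9-fold higher number from compound 2 to compound 4 (0.28 log units; within the scatter), so the only gap beyond the scatter in the set remains the one between compound 2 and compound 3. No measurement available accounts for this flat reading.

Open, as far as these compounds go, is whether an amine or a carboxylic acid on this same carbon would move the number beyond the scatter. Also open, from the compounds shown here alone, is whether 3-fluorophenyl would read like 4-fluorophenyl.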